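A few compounds are considered here, and "the series" means these few. Any claim that something is new, unique, unknown or untested is made for them only; others in the source may bear on it.

Measured so far in an assay on CHO cells for displacement of a labelled ligand from adenosine receptor A1 (Homo sapiens), read by scintillation counting, with a stated time of 90 min, tested at 1 uM; on this read-out higher numbers stand for more inhibition at the one concentration tested (going by the name of the read-out) and lower numbers for less inhibition:
- compound 1, `CC(=O)Nc1ccc(-c2c(C#N)c(N)nc(SCC(N)=O)c2C#N)cc1`, gives 17%
- compound 2, `N#Cc1c(N)nc(SCc2nnn[nH]2)c(C#N)c1-c1ccc(OCC2CC2)cc1`, gives 3%
- compound 3, `N#Cc1c(N)nc(SCc2nc3ccccc3[nH]2)c(C#N)c1-c1ccc(OCC2CC2)cc1`, gives 21%

Compound 3 holds the highest of the three numbers, but its gap to compound 1 lies within the scatter, so the two cannot be ordered; only compound 2 sits clearly lower. Within the data shown here, the one step that alters the group on the saturated chain carbon bound to a sulfur is a number 18 percentage points higher from compound 2 to compound 3 (beyond the scatter), a modest gain.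

Compound 4, `N#Cc1c(N)nc(SCC(N)=O)c(C#N)c1-c1ccc(OCC2CC2)cc1`, is not yet measured. Against compound 3 the change is carbamoyl in place of 1H-benzimidazol-2-yl on a saturated chain carbon bound to a sulfur. Among the measured compounds shown here, no measured step covers this exchange directly. Compound 1 carries the same carbamoylmethylsulfanyl chain as compound 4 on a different aryl group, and its value is within the scatter of compound 3; the pair is otherwise not a single-point change, so it shows only that a carbamoyl at this place can give a number close to that of compound 3. Given that the only relevant step, from the tetrazolyl to the benzimidazolyl, was modest, the step of a number 8 percentage points lower from compound 3 to compound 4 (within the scatter) is expected to be small and downward, possibly within the scatter. Compound 4 is therefore estimated at 13%, with a range from 2% to 28%.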

Compound 4, a percentage reported as inhibition, at one concentration (the size of the read-out at that concentration, not a potency): 31%
Estimate against measurement, compound 4: 18 percentage points below; the measured number lies above the stated range.
By their numbers in this assay, from the lowest: compound 2; then compounds 1, 3 and 4 (each within the scatter of the next, the first and the last beyond it).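

In this assay, the carbamoyl on a saturated chain carbon bound to a sulfur gives a result level with that of the 1H-benzimidazol-2-yl, with a number 10 percentage points higher from compound 3 to compound 4 (within the scatter), so on this aryl group the two aromatic rings and 9 heavy atoms of the leaving group are not required to keep the number, since a ringless group of 3 heavy atoms does as well. Against the 1H-tetrazol-5-yl the same exchange gives a number 28 percentage points higher from compound 2 to compound 4 (beyond the scatter), which leaves the tetrazolyl compound as the only one of the three clearly low among the groups tried at this place on the cyclopropylmethoxy-bearing aryl group. With the carbamoylmethylsulfanyl chain held fixed, the aryl substituent also proves to matter, with a number 14 percentage points higher from compound 1 to compound 4 (beyond the scatter), for cyclopropylmethoxy in place of acetamido on an aromatic carbon.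

Nothing available gives a reason for any of these numbers. Still open, on these data alone, are how a carboxylic acid, a methyl amide or a longer chain ending in the carbamoyl would read at this place, and what potency lies behind these single-concentration values.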